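Trimming the Amide Substituent on an Antiproliferative Scaffold

The source may hold more compounds than are shown below. What is called first, only, known or untested is meant among the compounds shown, and "the series" means these compounds.

Of the compounds shown here, two on a shared core have been tested in a functional assay on A549 cells (Homo sapiens) for antiproliferative activity, read by MTT assay, with a stated time of 72 h; on this read-out lower numbers stand for stronger inhibition and higher numbers for weaker inhibition. Compound 1 `Cn1cc(Nc2nn(Cc3ccc(C(=O)NC4CCCCC4)cc3)c(=O)c3ccccc23)cn1` gives 6800 nM in this assay. Among the compounds with values here, compound 2 `Cc1noc(C)c1-c1nn(Cc2ccc(C(=O)NC3CC(C)(C)N([O])C(C)(C)C3)cc2)c(=O)c2ccccc12` gives 84300 nM in this assay, the highest of the two numbers, and its distance from compound 1 lies beyond the scatter; since the two differ in more than one place, no single step links them. Compound 3 `Cc1noc(C)c1-c1nn(Cc2ccc(C(=O)N3CCCCC3)cc2)c(=O)c2ccccc12` has not yet been measured. It differs from compound 2 on a carbonyl carbon: a group of 6 heavy atoms (5 carbon, 1 nitrogen; one six-membered non-aromatic ring with 1 hetero atom) in place of a group of 12 heavy atoms (9 carbon, 2 nitrogen, 1 oxygen; one six-membered non-aromatic ring with 1 hetero atom), on a carbonyl carbon. Within the data shown here, no step between measured compounds bears on this change. Compound 3 is expected to give a lower number than compound 2, with an estimated step of a 4.2-fold lower number from compound 2 to compound 3 (0.62 log units; beyond the scatter). That expectation leans on compound 1, whose amide without the nitroxide-bearing ring gives 6800 nM in this assay, although compound 1 also differs from compound 3 elsewhere on the core. Compound 3 is estimated at 20000 nM, with a range from 4000 nM to 100000 nM.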

Compound 3, half-maximal inhibitory concentration: 86200 nM
For compound 3 the middle estimate is 4.3-fold (0.63 log units) below the measured one; the measured number falls inside the stated range.
By their numbers in this assay, from the lowest: compound 1; then compounds 2 and 3 (each within the scatter of the next).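

In this assay, placing piperidin-1-yl on the carbonyl carbon in place of the larger group gives a 1.0-fold higher number from compound 2 to compound 3 (0.01 log units; within the scatter). Within the data shown here, this is the first single-place step, and it shows that, with the rest of the molecule held fixed, this exchange leaves the read-out within the scatter, even though piperidin-1-yl has the lower heavy-atom count of the two groups and the hydrogen-bond donor and acceptor counted on the leaving group are absent from piperidin-1-yl. Nothing available here accounts for this result.

The compounds shown leave open whether the same exchange would behave alike on the core of compound 1, which no single step links to the other two. They also leave open how a morpholin-4-yl or a dimethylamino group on this carbonyl carbon would read.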